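A few compounds are considered here, and "the series" means these few. Any claim that something is new, unique, unknown or untested is made for them only; others in the source may bear on it.

Three compounds share one core and differ only in the tail that carries an aromatic ring. Compound 1 `CCCc1nc(-c2ccccc2)c(CNCCCN2CCN(c3ccc(F)cc3)CC2)o1` gives 3210 nM in an assay on HEK293 cells for inhibition of Voltage-dependent T-type calcium channel subunit alpha-1G (Homo sapiens), read by patch clamp; on this read-out lower numbers stand for stronger inhibition and higher numbers for weaker inhibition. Among the compounds with values here, compound 3 `CCCc1nc(-c2ccccc2)c(CNCCCN2CCN(c3ccc(C(F)(F)F)cc3)CC2)o1` gives 7250 nM, and the change a 2.3-fold higher number from compound 1 to compound 3 (0.35 log units; beyond the scatter) is the one step so far that swaps a small group on that ring for a larger one. Compound 2 `CCCc1nc(-c2ccccc2)c(CNCCN2CCN(c3ccccc3C(F)(F)F)CC2)o1` gives 2100 nM, the lowest of the three numbers; its gap to compound 1 lies within the scatter, and only compound 3 stands clearly apart from it.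

Compound 4 `CCCc1nc(-c2ccccc2)c(CNCCN2CCN(c3ccccc3C)CC2)o1` has not been measured. Its change from compound 2 is methyl in place of trifluoromethyl on an aromatic carbon. Within the data shown here, no measured step replaces a trifluoromethyl with a methyl, so only the step from compound 1 to compound 3 bears on it, and there a move to the bulkier trifluoromethyl gave a modestly higher number. Going the other way, toward the smaller group, compound 4 is therefore expected to show a 1.4-fold lower number from compound 2 to compound 4 (0.15 log units; within the scatter), a small shift toward a lower number or none beyond the scatter. The estimate for compound 4 is 1500 nM, within 600 nM to 4000 nM.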

Compound 4, half-maximal inhibitory concentration: 4300 nM
Compound 4: middle estimate off by 2.9-fold (0.46 log units), on the low side; the measured number lies above the stated range.
By their numbers in this assay, from the lowest: compounds 2, 1, 4 and 3 (each within the scatter of the next, the first and the last beyond it).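

In this assay, putting methyl in place of trifluoromethyl on this aromatic carbon, ortho to a large group, weakens inhibition modestly but beyond the scatter (a 2.0-fold higher number from compound 2 to compound 4 (0.31 log units; beyond the scatter)). The smaller group therefore gives the higher number in this pair, whereas the larger trifluoromethyl gave the higher number in the earlier step (a 2.3-fold higher number from compound 1 to compound 3 (0.35 log units; beyond the scatter)), which replaced fluoro in a compound with a different tail, so across these two steps trifluoromethyl shows no single direction. No measurement shown here accounts for this difference.

The compounds shown leave open how chloro, methoxy or a plain hydrogen on this carbon would compare with trifluoromethyl and methyl. They also leave open whether the same swap would give a similar step on the tail of compound 1.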